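Swapping Methoxy for Chloro: Expected Cytotoxicity of Compound 4

This account rests on a few compounds, and the source may have more. Where it says the series, first, only, none or still open, it means among the compounds named here.

Of the compounds shown here, three have so far been tested in an ADME assay on NIH3T3 cells (Mus musculus) for cytotoxicity, read by MTT assay, with a stated time of 24 h; on this read-out lower numbers stand for stronger inhibition and higher numbers for weaker inhibition. Compound 1 `COc1ccc(N2CCN(CC(=O)N3CCN(c4nnc(-c5ccccc5)c(-c5ccccc5)n4)CC3)CC2)cc1` gives > 910000 nM there, which is a limit of the measurement rather than a number. Compound 2 `O=C(CN1CCN(c2ccc(Cl)cc2)CC1)N1CCN(c2nnc(-c3ccccc3)c(-c3ccccc3)n2)CC1` gives 113000 nM in this assay. The two differ by chloro in place of methoxy on an aromatic carbon, and the step of an at least 8.0-fold lower number from compound 1 to compound 2 (0.90 log units; beyond the scatter) can only be stated as a bound because of the limit of > 910000 nM in this assay, at which 1 of the 3 values shown sits. Compound 3 `COc1ccccc1N1CCN(CC(=O)N2CCN(c3nnc(-c4ccc(Cl)cc4)c(-c4ccc(Cl)cc4)n3)CC2)CC1` gives 405000 nM in this assay, the highest number among the measured compounds; how its core differs from the core of compound 1 is not broken down here.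

Compound 4 `O=C(CN1CCN(c2ccccc2Cl)CC1)N1CCN(c2nnc(-c3ccc(Cl)cc3)c(-c3ccc(Cl)cc3)n2)CC1` has not yet been measured. It differs from compound 3 by chloro in place of methoxy on an aromatic carbon. Among the compounds with values here, this is the same kind of change as the one between compound 1 and compound 2, but here the chloro sits ortho to a large group rather than para to it, so the two steps need not match in size. Resting on an at least 8.0-fold lower number from compound 1 to compound 2 (0.90 log units; beyond the scatter), a lower number is expected for compound 4, with a step of a 3.1-fold lower number from compound 3 to compound 4 (0.49 log units; beyond the scatter) estimated. Compound 4 is therefore estimated at 130000 nM, within a range from 45000 nM to 380000 nM.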

Compound 4, half-maximal inhibitory concentration: > 803000 nM
Compound 4: a limit, no number; the forecaster's own chance of this, stated with the estimate: 5%; at least 6.1-fold (0.79 log units) between middle value and limit.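

In this assay, replacing 2-methoxyphenyl with 2-chlorophenyl gives an at least 1.9-fold higher number from compound 3 to compound 4 (0.29 log units; that floor lies within the scatter), so the drop seen on the other core does not carry over, and the two steps differ: the same change on two cores in this assay, an at least 8.0-fold lower number (0.90 log units; beyond the scatter) from compound 1 to compound 2 and an at least 1.9-fold higher number (0.29 log units; that floor lies within the scatter) from compound 3 to compound 4, at least 15-fold (1.20 log units) apart, beyond the scatter of two such steps The new step can be stated only as a bound, so its true size remains unknown: the limit of > 803000 nM in this assay, at which 1 of the 4 values shown sits. This does not show why the steps differ, since the chloro in compound 4 sits ortho to a large group and its core also differs from that of compound 2, and these few compounds cannot separate those two differences.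

Still open, from the compounds shown here alone, is how a 2-chlorophenyl group would read on the core of compound 1, a comparison that would help separate the place of the chloro from the effect of the core. Also open, going by these compounds, is whether another group in the same place, such as fluoro or methyl, would move the number in the same direction on both cores.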